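Trifluoromethylphenyl Urea Arm Swapped for Dichlorophenyl

The source may hold more compounds than are shown below. What is called first, only, known or untested is meant among the compounds shown, and "the series" means these compounds.

Measured compounds:
Compound 1 `O=C(Nc1cccc(-n2cc(-c3ccncc3)c(-c3ccc(Cl)c(O)c3)n2)c1)Nc1cccc(C(F)(F)F)c1` gives > 32500 nM in a functional assay on OVCAR-4 cells (Homo sapiens) for inhibition, read by sulforhodamine B assay, with a stated time of 48 h; on this read-out lower numbers stand for higher toxicity in this test and higher numbers for lower toxicity in this test; this is a limit of the assay, not a number.
Compound 2 `COc1cc(-c2nn(-c3cccc(NC(=O)Nc4cc(C(F)(F)F)cc(C(F)(F)F)c4)c3)cc2-c2ccncc2)ccc1Cl` gives > 50000 nM in this assay; this too is a limit.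

On the numbers shown, compound 1 stands only at a limit, (the limit of > 32500 nM in this assay, at which 1 of the 2 values shown sits), and compound 2 at another, (the limit of > 50000 nM in this assay, at which 1 of the 2 values shown sits); neither shows a measurable cell-killing concentration within the tested range, and no measured step between two compounds exists here.

Compound 3 `O=C(Nc1cccc(-n2cc(-c3ccncc3)c(-c3ccc(Cl)c(O)c3)n2)c1)Nc1ccc(Cl)c(Cl)c1` differs from compound 1 in one place, 3,4-dichlorophenyl in place of 3-(trifluoromethyl)phenyl on an amide-type nitrogen. With compound 1 unmeasured beyond its limit, no size of step can be read; the expected change is none beyond the scatter. Compound 3 is therefore expected to give 40000 nM, within 10000 nM to 120000 nM, most probably reported again only as a limit. This estimate means a step that the limit leaves unreadable from compound 1 to compound 3, expected to be none beyond the usual scatter.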

Compound 3, concentration lethal to 50% of the cells: > 32500 nM
Compound 3 ended at the assay's limit; the forecaster's own chance of this, stated with the estimate: 80%; the middle value lies beyond the limit too.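

In this assay compound 3 gives > 32500 nM, which is a limit of the assay and not a number. Within the data shown here, compound 1 also stands at a limit, so no step between compound 1 and compound 3 can be read. The compounds shown leave open whether changing the urea arm alters toxicity to these cells at all.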